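Chloro Versus Ethyl on the Aromatic Ring

A few compounds are considered here, and "the series" means these few. Any claim that something is new, unique, unknown or untested is made for them only; others in the source may bear on it.

Compound 1 `CC(C)c1ccc(OC(C)(Cc2cccc(Cl)c2)C(=O)O)cc1`: 5 mg/kg
Compound 2 `CCc1ccccc1CC(C)(Oc1ccc(C(C)C)cc1)C(=O)O`: 5 mg/kg
Compound 3 `CCc1cccc(CC(C)(Oc2ccc(C(C)C)cc2)C(=O)O)c1`: 0.5 mg/kg

In a functional assay on the whole organism for inhibition, with Rattus norvegicus as the target (on this read-out higher numbers stand for an effect only at larger amounts of compound and lower numbers for an effect already at smaller amounts), compound 3 gives 0.5 mg/kg, the lowest of the three numbers. Compound 4 `CC(C)c1ccc(OC(C)(Cc2ccc(Cl)c(Cl)c2)C(=O)O)cc1` differs from it in one group: 3,4-dichlorophenyl in place of 3-ethylphenyl on a saturated chain carbon, two bonds along the chain from a carbonyl carbon and an oxygen on an aromatic ring. The nearest evidence is a 10-fold lower number from compound 1 to compound 3 (1.00 log units; beyond the scatter), with ethyl in place of chloro on an aromatic carbon. Reversing that exchange would be expected to raise the number by a similar amount. The other step to compound 3, a 10-fold lower number from compound 2 to compound 3 (1.00 log units; beyond the scatter), involves no chloro group. For the measured compounds named here, no measured compound carries 3,4-dichlorophenyl, so that group's own contribution remains open. The expected change is a 6.0-fold higher number from compound 3 to compound 4 (0.78 log units; beyond the scatter). For compound 4 the estimated value is 3 mg/kg, with an expected range of 0.7 mg/kg to 10 mg/kg.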

Compound 4, dose for half-maximal effect: 5 mg/kg
Beside the measured number, compound 4's estimate is 1.7-fold (0.22 log units) below it; the range from low to high includes it.
By their numbers in this assay, from the lowest: compound 3; then compounds 1, 2 and 4 (each within the scatter of the next).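

Chloro in place of hydrogen on an aromatic carbon gives (no change at the digits printed from compound 1 to compound 4 (within the scatter)), so in this assay the added chloro shows no effect beyond the scatter. In place of 3-ethylphenyl, 3,4-dichlorophenyl gives (a 10-fold higher number from compound 3 to compound 4 (1.00 log units; beyond the scatter)), whereas in place of 2-ethylphenyl it gives (no change at the digits printed from compound 2 to compound 4 (within the scatter)). Among these four compounds, only compound 3, with 3-ethylphenyl, stands apart at this saturated chain carbon.

Nothing available here accounts for this difference. Going by these compounds, it also remains open whether a propyl or methoxy group in place of the ethyl of compound 3 would keep its low number.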